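A few compounds are considered here, and "the series" means these few. Any claim that something is new, unique, unknown or untested is made for them only; others in the source may bear on it.

For the measured compounds named here, in a functional assay on NPC-TW01 cells (Homo sapiens) for inhibition, read by MTT assay, with a stated time of 72 h (on this read-out lower numbers stand for stronger inhibition of growth and higher numbers for weaker inhibition of growth), compound 2 `COC(=O)c1nc(C)n(-c2ccc(F)cc2)n1` gives 15200 nM, the only number measured here. Compound 1 `COC(=O)c1nc(C)n(-c2ccccc2)n1` gives > 100000 nM in this assay, which is a limit rather than a number (the limit of > 100000 nM in this assay, at which 1 of the 2 values shown sits). The step of an at least 6.5-fold lower number from compound 1 to compound 2 (0.81 log units; beyond the scatter) concerns a different change and does not bear on what follows. Compound 3 `COC(=O)c1nc(-c2ccccc2)n(-c2ccc(F)cc2)n1` differs from compound 2 by phenyl in place of methyl on an aromatic carbon, the change sitting between two ring nitrogen atoms of the shared core. Going by the values given here, no measured step covers this change, so compound 3 is expected to give roughly 10000 nM in this assay, between 2000 nM and 50000 nM, a step of a 1.5-fold lower number from compound 2 to compound 3 (0.18 log units; within the scatter).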

Compound 3, concentration for 50% growth inhibition: 15600 nM
For compound 3 the middle estimate is 1.6-fold (0.19 log units) below the measured one; low and high end bracket the measured number.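

Until now, nothing showed what this position between two ring nitrogen atoms tolerates. In this assay, phenyl in place of methyl gives a 1.0-fold higher number from compound 2 to compound 3 (0.01 log units; within the scatter), so a six-membered aromatic ring can stand where methyl stood and the two compounds cannot be told apart on growth inhibition. Nothing given here bears on why this is so.

From the compounds shown here alone, whether an amine, a carboxylic acid or a longer chain at this position would give a similar number stays open. So does whether phenyl here would give a similar number with hydrogen in place of the fluoro.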